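Bromo to trifluoromethyl on a bridged nucleotide analogue

A few compounds are considered here, and "the series" means these few. Any claim that something is new, unique, unknown or untested is made for them only; others in the source may bear on it.

Compound 1, `COP1(=O)OC[C@H]2O[C@@H](n3cc(Br)c(=O)[nH]c3=O)C[C@@H]2O1`: > 100 ug/mL
Compound 2, `O=c1[nH]c(=O)n([C@H]2C[C@H](O)[C@@H](COP(=O)(O)O)O2)cc1C(F)(F)F`: 0.169 ug/mL
Compound 3, `O=c1[nH]c(=O)n([C@H]2C[C@@H]3O[PH](O)(O)OC[C@H]3O2)cc1Br`: 224 ug/mL

In a functional assay (Raji cells) for antiproliferative activity, with Homo sapiens as the target (on this read-out lower numbers stand for stronger inhibition and higher numbers for weaker inhibition), compound 1 reaches only a limit, > 100 ug/mL, and no number. Compound 3 gives 224 ug/mL in this assay, the highest of the two numbers shown, while compound 2 gives 0.169 ug/mL, a far lower number that lies well beyond the scatter of compound 3. Compound 4, `O=c1[nH]c(=O)n([C@H]2C[C@@H]3O[PH](O)(O)OC[C@H]3O2)cc1C(F)(F)F`, is not yet measured; it differs from compound 3 in one place: trifluoromethyl in place of bromo on an aromatic carbon. Compound 2 carries the same trifluoromethyl on a different phosphorus arrangement, so the step in this assay is expected to be large and toward a lower number, a 45-fold lower number from compound 3 to compound 4 (1.65 log units; beyond the scatter), though uncertain. Compound 4 is therefore estimated at 5 ug/mL, between 0.3 ug/mL and 100 ug/mL.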

Compound 4, concentration for 50% inhibition: 1.81 ug/mL
The estimate for compound 4 lay 2.8-fold (0.44 log units) above the measured number; low and high end bracket the measured number.
By their numbers in this assay, from the lowest: compound 2; then compound 4; then compound 3.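

In this assay trifluoromethyl in place of bromo on an aromatic carbon gives a 120-fold lower number from compound 3 to compound 4 (2.09 log units; beyond the scatter) on an otherwise unchanged core. Among the compounds shown here, this is the first pair that isolates this position, and it shows that this single change is enough for a large step. Compound 1 gives only a limit, so it offers no number for comparison: the limit of > 100 ug/mL in this assay, at which 1 of the 4 values shown sits.

From the compounds shown here alone, whether an amine, a nitrile or a longer chain in the same place would give a lower or higher number stays open. So does whether the same change would give a step of similar size on the core of compound 1.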